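This account rests on a few compounds, and the source may have more. Where it says the series, first, only, none or still open, it means among the compounds named here.

Measured so far:
compound 1, `CC(C)(C)OC(=O)NCNC(=O)CN1CN(c2ccccc2)C2(CCN(C(=O)c3ccc(C4CCCCC4)cc3)CC2)C1=O`, 1700 nM
compound 2, `CS(=O)(=O)NCCNC(=O)CN1CN(c2ccccc2)C2(CCN(C(=O)c3ccc(C4CCCCC4)cc3)CC2)C1=O`, 2100 nM

Both compounds share one core and differ only in the tail of the side chain on the amide-type nitrogen. In an assay on HEK293 cells for displacement of a labelled ligand from NPC1-like intracellular cholesterol transporter 1 (Homo sapiens) (a higher number here means a weaker inhibitor, a lower number a stronger inhibitor), compound 1 gives 1700 nM and compound 2 gives 2100 nM. Going by the values given here, the one step measured so far, a 1.2-fold higher number from compound 1 to compound 2 (0.09 log units; within the scatter), lies within the scatter, so compound 2 cannot be separated from compound 1 on these two numbers; the pair sits at the same level.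

Compound 3, `O=C(CN1CN(c2ccccc2)C2(CCN(C(=O)c3ccc(C4CCCCC4)cc3)CC2)C1=O)NCCCCO`, has not yet been measured. It differs from compound 2 as follows: 2-hydroxyethyl in place of methanesulfonamido on a saturated chain carbon, two bonds along the chain from an amide-type nitrogen. Among the compounds with values here, the only step that bears on this change is the exchange of side-chain tails from compound 1 to compound 2, which was within the scatter. Within the data shown here, that exchange is the sole guide, and it gives no hint of movement in either direction. The expectation for compound 3 is therefore a step of a 1.1-fold lower number from compound 2 to compound 3 (0.02 log units; within the scatter), that is, no change beyond the scatter. Compound 3 is estimated at 2000 nM, with a range from 900 nM to 4500 nM.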

Compound 3, half-maximal inhibitory concentration: 10300 nM
Compound 3: middle estimate off by 5.2-fold (0.71 log units), on the low side; the measured number lies above the stated range.
By their numbers in this assay, from the lowest: compounds 1 and 2 (each within the scatter of the next); then compound 3.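

In this assay the tail on the side chain is not indifferent to every exchange: 2-hydroxyethyl in place of methanesulfonamido, on a saturated chain carbon two bonds along the chain from an amide-type nitrogen, gives a 4.9-fold higher number from compound 2 to compound 3 (0.69 log units; beyond the scatter), and 3-hydroxypropyl in place of (tert-butoxycarbonyl)amino gives a 6.1-fold higher number from compound 1 to compound 3 (0.78 log units; beyond the scatter). Going by these compounds alone, the earlier pair showed only that two different tails can sit at one level, with a 1.2-fold higher number from compound 1 to compound 2 (0.09 log units; within the scatter), whereas the hydroxy-ended 4-hydroxybutyl tail of compound 3 is the first to separate from them, and it does so against both. No measurement at hand bears on why the number rises with this exchange.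

The three compounds leave open whether the terminal hydroxyl or the 4-hydroxybutyl chain as a whole sets the higher number, a question that a shorter hydroxyalkyl chain, a methoxy-ended butyl chain, or an amine or carboxylic acid at the end of the same chain could address. Also open, on these data alone, is whether any tail at this position brings the number clearly below those of compound 1 and compound 2.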